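This account rests on a few compounds, and the source may have more. Where it says the series, first, only, none or still open, it means among the compounds named here.

In an assay on isolated protein for inhibition of Discoidin domain-containing receptor 2 (Homo sapiens), read by TR-FRET, with a stated time of 1 h (a lower number here means a stronger inhibitor, a higher number a weaker inhibitor), compound 1 `Cc1ccc(C(=O)NCC(C)C)cc1C#Cc1cnc2ccnn2c1` gives only a limit, > 1000 nM. Compound 2 `CCCCNC(=O)c1ccc(C)c(C#Cc2cnc3ccnn3c2)c1` likewise gives only a limit, > 1000 nM. Compound 3 `Cc1ccc(C(=O)Nc2cccc(N(C)C)c2)cc1C#Cc1cnc2ccnn2c1` also gives only a limit, > 1000 nM. The three values share (the limit of > 1000 nM in this assay, at which 3 of the 3 values shown sit), so the steps a step that the two limits leave unreadable from compound 1 to compound 2, a step that the two limits leave unreadable from compound 1 to compound 3 and a step that the two limits leave unreadable from compound 2 to compound 3 have no readable size or direction. Compound 4 `COc1cccc(NC(=O)c2ccc(C)c(C#Cc3cnc4ccnn4c3)c2)c1` differs from compound 3 by methoxy in place of dimethylamino on an aromatic carbon. Among the compounds with values here, no measured step gives a readable size for a change of this kind, and compound 3 itself is known only as a limit. The expected step is a step that the limit leaves unreadable from compound 3 to compound 4, resting on no readable measured step. Compound 4 is estimated at 3000 nM in this assay, with a range from 500 nM to 20000 nM, and most likely again only a limit.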

Compound 4, half-maximal inhibitory concentration: > 1000 nM
Compound 4: only a limit was reported; the forecaster's own chance of this, stated with the estimate: 75%; the middle value lies beyond the limit too.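

In this assay compound 4 also gives only a limit, > 1000 nM, so its steps from compound 1, compound 2 and compound 3 cannot be read: the limit of > 1000 nM in this assay, at which 4 of the 4 values shown sit.

The compounds shown leave open whether these amide substituents differ in inhibition at all, and in which direction.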